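The source may hold more compounds than are shown below. What is called first, only, known or untested is meant among the compounds shown, and "the series" means these compounds.

In an ADME assay on J774.A1 cells (Mus musculus) for cytotoxicity, read by MTT assay, with a stated time of 72 h (on this read-out higher numbers stand for lower toxicity in this test and lower numbers for higher toxicity in this test), compound 1 `CC1(c2ccc(-c3ccco3)cc2)CC(S(=O)(=O)c2ccc(F)cc2)=C(c2ccc(/C(N)=N\O)cc2)O1` gives 4560 nM. Among the three compounds measured, compound 1 has the lowest number and so the highest toxicity in this test. For the measured compounds named here, compound 2 `CC1(Cc2ccccc2)CC(S(=O)(=O)c2c(F)cccc2F)=C(c2ccc(/C(N)=N\O)cc2)O1` gives 27000 nM, and compound 3 `CC1(Cc2ccccc2)CC(S(=O)(=O)c2ccc(F)cc2F)=C(c2ccc(/C(N)=N\O)cc2)O1` gives 41500 nM; both stand beyond the scatter above compound 1, but each differs from compound 1 in two places, so no single step links them to it. Going by the values given here, the only single-place step available, a 1.5-fold higher number from compound 2 to compound 3 (0.19 log units; within the scatter), changes the fluorine pattern on the ring attached to the sulfonyl sulfur and does not reach beyond the scatter.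

Compound 4 `CC1(c2ccc(-c3ccc(/C(N)=N\O)cc3)cc2)CC(S(=O)(=O)c2ccc(F)cc2)=C(c2ccc(/C(N)=N\O)cc2)O1` differs from compound 1 at one place: a group of 10 heavy atoms (7 carbon, 2 nitrogen, 1 oxygen; one six-membered aromatic ring of carbon only) in place of a group of 5 heavy atoms (4 carbon, 1 oxygen; one five-membered aromatic ring with 1 hetero atom), on an aromatic carbon The entering group sits para to a large group, and it repeats a group already present elsewhere in compound 1. Among the compounds with values here, no measured step touches this position, so the step from compound 2 to compound 3 only says that a small change elsewhere left the number in this assay about where it was.

With nothing pointing in either direction, the number for compound 4 is expected to stay near that of compound 1, the estimated step being a 1.5-fold higher number from compound 1 to compound 4 (0.19 log units; within the scatter). Compound 4 is therefore estimated at 7000 nM, with a range from 2500 nM to 22000 nM.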

Compound 4, half-maximal cytotoxic concentration: 3940 nM
Compound 4: the middle estimate sits 1.8-fold (0.25 log units) above what was measured; the measured number falls inside the stated range.
By their numbers in this assay, from the lowest: compounds 4 and 1 (each within the scatter of the next); then compounds 2 and 3 (each within the scatter of the next).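

At this position, on an aromatic carbon para to a large group, the ring with its added 2 hydrogen-bond donors was tried in place of furan-2-yl, and this assay shows a 1.2-fold lower number from compound 1 to compound 4 (0.06 log units; within the scatter) with no difference beyond the scatter. So this site accepts a group of 10 heavy atoms, a second six-membered aromatic ring included, in place of one of 5 heavy atoms, with the number staying in the same range, and the toxicity in this test stays at the level of compound 1 rather than reaching the level of compound 2 and compound 3. Nothing measured here explains why the two groups read alike, and no supporting evidence is available on that point.

As far as these compounds go, only these two groups have been seen at this position, so it remains open whether a small group such as methyl, a basic amine or a carboxylic acid would leave the number in the same range. From the compounds shown here alone, it is also open whether the same exchange would read alike on a compound with a different ring on the sulfonyl sulfur, such as the 2,4-difluorophenyl of compound 3.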